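Cytotoxicity notes on removing the cyano group

The source may hold more compounds than are shown below. What is called first, only, known or untested is meant among the compounds shown, and "the series" means these compounds.

Measured so far:
compound 1 `COc1cccc(-c2cc(C)c3ncc(CSCCc4ccccc4)n3c2)c1` — 20 ug/mL
compound 2 `Cc1cc(-c2ccc(C#N)cc2)cn2c(CSCCc3ccccc3)cnc12` — >= 20 ug/mL

In an ADME assay on HEL cells (Homo sapiens) for cytotoxicity, with a stated time of 3 days (a higher number here means that more compound is tolerated, a lower number that less compound is tolerated), compound 1 gives 20 ug/mL. For compound 2 the result is a limit of the assay, >= 20 ug/mL, and (the limit of >= 20 ug/mL in this assay, at which 1 of the 2 values shown sits). The measured step of a number no lower from compound 1 to compound 2 (the limit leaves the size open) therefore has no readable size. Compound 3 `Cc1cc(-c2ccccc2)cn2c(CSCCc3ccccc3)cnc12` differs from compound 2 by hydrogen in place of cyano on an aromatic carbon. Going by the values given here, only that one step bears on the change, and it shows nothing beyond the scatter, so for compound 3 a step of a number no higher from compound 2 to compound 3 (the limit leaves the size open) is expected in this assay. Compound 3 is estimated at 20 ug/mL, in the range 10 ug/mL to 40 ug/mL.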

Compound 3, minimum cytotoxic concentration: 20 ug/mL
Compound 3: the middle estimate sits on the measured number at the digits printed; the range from low to high includes it.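

Removing the nitrile from the phenyl ring gives a number no higher from compound 2 to compound 3 (the limit leaves the size open) in this assay. Compound 2 stands at a limit of the assay. Going by these compounds alone, the one readable step is no change at the digits printed from compound 1 to compound 3 (within the scatter), so hydrogen and methoxy do not separate on this ring. The steps involving compound 2 cannot be read: the limit of >= 20 ug/mL in this assay, at which 1 of the 3 values shown sits.

Going by these compounds, how far the tolerated concentration of compound 2 extends past its limit remains open. So does how an amine or a carboxylic acid on this phenyl ring would read in this assay.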